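The source may report more compounds than this note shows. Statements on the series, on what has been measured and on what is new or still open speak of the compounds shown alone.

Notes on the series. In an ADME assay on HEK293 cells for displacement of a labelled ligand from 5-hydroxytryptamine receptor 6 (Homo sapiens), read by radioligand binding, with a stated time of 1 h (a lower number here means a stronger inhibitor, a higher number a weaker inhibitor), compound 1 `O=C1c2ccccc2S(=O)(=O)N1CCCCCCN1CCN(c2ccccc2F)CC1` gives 1620 nM, compound 2 `O=C1c2ccccc2S(=O)(=O)N1CCCCCCN1CCN(c2cccc(Cl)c2)CC1` gives 372 nM and compound 3 `O=C1c2ccccc2S(=O)(=O)N1CCCCCCN1CCN(c2ccccc2C(F)(F)F)CC1` gives 1270 nM. Compound 3 stands second highest of these three numbers; its nearest neighbour is compound 1 (a 1.3-fold lower number from compound 1 to compound 3 (0.11 log units; within the scatter)), its furthest compound 2 (a 3.4-fold higher number from compound 2 to compound 3 (0.53 log units; beyond the scatter)). Compound 4 `O=C1c2ccccc2S(=O)(=O)N1CCCCCCN1CCN(c2cccc3ccccc23)CC1` is not yet measured in this assay and differs from compound 3 by naphthalen-1-yl in place of 2-(trifluoromethyl)phenyl on an amine nitrogen in a ring. Two earlier exchanges of the group on the amine nitrogen in a ring bear on this step: a 4.4-fold lower number from compound 1 to compound 2 (0.64 log units; beyond the scatter) and a 3.4-fold higher number from compound 2 to compound 3 (0.53 log units; beyond the scatter), both modest and both beyond the scatter. A step of comparable size towards a lower number is expected here, so compound 4 is estimated at 500 nM, with a range from 150 nM to 1600 nM. That estimate corresponds to an expected 2.5-fold lower number from compound 3 to compound 4 (0.40 log units; beyond the scatter).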

Compound 4, inhibition constant: 157 nM
Estimate against measurement, compound 4: 3.2-fold (0.50 log units) above; the range from low to high includes it.
By their numbers in this assay, from the lowest: compound 4; then compound 2; then compounds 3 and 1 (each within the scatter of the next).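

On the amine nitrogen in a ring, naphthalen-1-yl gives the lowest number of the four compounds, with every step beyond the scatter (an 8.1-fold lower number from compound 3 to compound 4 (0.91 log units; beyond the scatter); a 2.4-fold lower number from compound 2 to compound 4 (0.37 log units; beyond the scatter); a 10-fold lower number from compound 1 to compound 4 (1.01 log units; beyond the scatter)). Among the compounds shown here, compound 4 shows that 2 six-membered aromatic rings of carbon only are tolerated here and outperform the single ring of compounds 1, 2 and 3. Nothing at hand explains this gain.

Open, going by these compounds, is whether the attachment point matters, as naphthalen-2-yl would show. Also open, on these data alone, is whether a quinolinyl group, carrying a ring nitrogen, or a shorter chain preserves the gain.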